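This account rests on a few compounds, and the source may have more. Where it says the series, first, only, none or still open, it means among the compounds named here.

Measured compounds:
- compound 1 `O=C(Oc1ccccc1)c1cc2cc(CCl)ccc2oc1=O`: > 50000 nM
- compound 2 `Cc1ccc2oc(=O)c(C(=O)Nc3ccccc3)cc2c1`: 23000 nM

In an assay on isolated protein for inhibition of coagulation factor XII (Homo sapiens) (a lower number here means a stronger inhibitor, a higher number a weaker inhibitor), compound 1 gives only a limit of the assay, > 50000 nM (the limit of > 50000 nM in this assay, at which 1 of the 2 values shown sits). Among the compounds with values here, compound 2 is therefore the only compound with a number in this assay, at 23000 nM. Compound 3 `Cc1ccc2oc(=O)c(C(=O)Nc3ccccc3C)cc2c1` differs from compound 2 by methyl in place of hydrogen on an aromatic carbon, in words a methyl in place of hydrogen on an aromatic carbon. Within the data shown here, no measured step of this kind exists, so no change beyond the usual scatter is expected, and a 1.2-fold lower number from compound 2 to compound 3 (0.06 log units; within the scatter) is the estimated step. Compound 3 is expected at 20000 nM, within 7000 nM to 60000 nM.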

Compound 3, half-maximal inhibitory concentration: 32000 nM
Estimate against measurement, compound 3: 1.6-fold (0.20 log units) below, within the range that was stated.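

In this assay, within the data shown here, the first measured step, phenyl to 2-methylphenyl, gives a 1.4-fold higher number from compound 2 to compound 3 (0.14 log units; within the scatter). A methyl in place of hydrogen on this aromatic carbon, ortho to a large group, therefore leaves the number within the scatter, and the shared core with its amide link carries this change without a clear gain or loss. No measurement shown bears on a cause for this step.

Going by these compounds, whether an amine, a methoxy or a carboxylic acid at this place would move the number beyond the scatter stays open. So does the outcome of the same methyl on other carbons of the phenyl ring.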